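Side-chain changes on the triple-bonded carbon

The compounds below may be only part of what the source reports. "The series", "measured", "known", "first", "only" and "open" are said of these compounds alone.

Measured in a functional assay on MDA-MB-435 cells (Homo sapiens) for inhibition; a lower number here means a stronger inhibitor, a higher number a weaker inhibitor:
Compound 1, `COc1cc[nH]c1/C=C1/C(=O)Nc2ccc(F)cc21`: only a limit, > 30000 nM.
Compound 2, `COc1cc[nH]c1/C=C1\C(=O)Nc2ccc(F)c(C#C[C@@H](C)O)c21`: 110 nM.
Compound 3, `COc1cc[nH]c1/C=C1\C(=O)Nc2ccc(F)c(C#C[C@H](N)CO)c21`: 320 nM.

Compound 3 gives the higher of the two numbers available; its nearest neighbour is compound 2, with a 2.9-fold higher number from compound 2 to compound 3 (0.46 log units; beyond the scatter). Compound 1 sits at the limit of > 30000 nM in this assay, at which 1 of the 3 values shown sits, so it contributes no number to compare against.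

Compound 4, `CN[C@H](C#Cc1c(F)ccc2c1/C(=C/c1[nH]ccc1OC)C(=O)N2)[C@@H](C)O`, is not yet measured. It differs from compound 3 by 2-hydroxy-1-(methylamino)propyl in place of 1-amino-2-hydroxyethyl on a triple-bonded carbon. Within the data shown here, the only measured step that bears on this position is a 2.9-fold higher number from compound 2 to compound 3 (0.46 log units; beyond the scatter), a modest move that followed exchange of one small hydroxyl-bearing side chain for another on the same triple-bonded carbon. The change to compound 4 again swaps one such side chain for a somewhat larger one at the same place, with an additional stereocentre. Among the measured compounds shown here, with a single step of modest size as the only guide, a shift of similar or smaller magnitude is expected, in either direction, most likely within or just beyond the scatter. Compound 4 is therefore estimated at 250 nM in this assay, with a range of 80 nM to 800 nM. On that basis the expected step reads a 1.3-fold lower number from compound 3 to compound 4 (0.11 log units; within the scatter).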

Compound 4, half-maximal inhibitory concentration: 358 nM
Compound 4: the middle estimate sits 1.4-fold (0.16 log units) below what was measured; the measured number falls inside the stated range.
By their numbers in this assay, from the lowest: compound 2; then compounds 3 and 4 (each within the scatter of the next). At a limit, above all of these: compound 1.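

In this assay, 2-hydroxy-1-(methylamino)propyl and 1-amino-2-hydroxyethyl on a triple-bonded carbon cannot be told apart (a 1.1-fold higher number from compound 3 to compound 4 (0.05 log units; within the scatter)). This position therefore accepts the larger side chain, with its methylated nitrogen and second defined stereocentre, with no readable difference from the smaller amino side chain. Against 1-hydroxyethyl, the larger side chain gives a step beyond the scatter (a 3.3-fold higher number from compound 2 to compound 4 (0.51 log units; beyond the scatter)), so both amino-bearing side chains shown now sit on the same side of compound 2, a pattern that rests on compound 3 and compound 4 alone, with neither going against it.

Still open, going by these compounds, is whether that gap follows the amine or the added chain, which a 4-hydroxypent-1-yn-1-yl side chain without the amine, a dimethylamino analogue or the opposite configuration at either stereocentre could separate. The measurements shown offer no reason for the gap or for the match between the two amino-bearing side chains.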